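The source may hold more compounds than are shown below. What is called first, only, known or untested is meant among the compounds shown, and "the series" means these compounds.

Compound 1 `Cc1cc(CO)nc(NNC(=O)Nc2cc(Cl)nc(Cl)c2)c1` is one anchor of the series. In a functional assay on CHO cells for antagonist activity at sphingosine 1-phosphate receptor 2 (Homo sapiens), read by fluorescence and calcium flux, with a stated time of 3 min (on this read-out higher numbers stand for weaker inhibition and lower numbers for stronger inhibition), compound 1 gives only a limit, > 6600 nM. Compound 2 `Cc1cc(NNC(=O)Nc2cc(Cl)nc(Cl)c2)nc(-c2cnn(C)c2)c1` likewise returns a limit, > 2100 nM, in this assay. Within the data shown here, the single measured step that the two limits leave unreadable from compound 1 to compound 2 is therefore unreadable, and compound 2 stands at the limit of > 2100 nM in this assay, at which 1 of the 2 values shown sits, with the other value at the limit of > 6600 nM in this assay, at which 1 of the 2 values shown sits; no number is fixed for either. Compound 3 `Cc1cc(NNC(=O)Nc2cc(Cl)nc(Cl)c2)nc(-c2ccc(F)cc2)c1` arises by the change (4-fluorophenyl in place of 1-methyl-1H-pyrazol-4-yl on an aromatic carbon). Only the unreadable step bears on this change, so no size of step is expected in this assay, in either direction. Compound 3 is estimated at 5000 nM, within 1500 nM to 30000 nM. The expected step is a step that the limit leaves unreadable from compound 2 to compound 3.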

Compound 3, half-maximal inhibitory concentration: 1300 nM
Compound 3: the middle estimate sits 3.8-fold (0.59 log units) above what was measured, and the stated range ends above it.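

With 4-fluorophenyl on this aromatic carbon next to the ring nitrogen, compound 3 is the only compound shown that gives a number rather than a limit in this assay. In place of hydroxymethyl, this change gives an at least 5.0-fold lower number from compound 1 to compound 3 (0.70 log units; beyond the scatter), whereas in place of 1-methyl-1H-pyrazol-4-yl it gives only an at least 1.6-fold lower number from compound 2 to compound 3 (0.20 log units; that floor lies within the scatter). The second step stays a floor, as compound 2 gives only a limit: the limit of > 2100 nM in this assay, at which 1 of the 3 values shown sits.

Whether the fluorine contributes to the value of compound 3 stays open, with no unsubstituted phenyl among these compounds. Going by these compounds, how an amine or a carboxylic acid at this position would read also remains unknown.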